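From 3-chlorophenyl to pyridin-3-yl on the shared core

A few compounds are considered here, and "the series" means these few. Any claim that something is new, unique, unknown or untested is made for them only; others in the source may bear on it.

Compound 1 `O=C(O)c1cncc(-n2cc(CO[C@H]3O[C@H](CO)[C@@H](O)[C@H](O)[C@@H]3O)nn2)c1`, compound 2 `Cc1ccc(-c2cn(C[C@H]3O[C@H](CO)[C@@H](O)[C@H](O)[C@@H]3O)nn2)cc1` and compound 3 `OC[C@H]1O[C@H](Cn2cc(-c3cccc(Cl)c3)nn2)[C@@H](O)[C@@H](O)[C@@H]1O` share a sugar-bearing triazole design and were taken into a physicochemical assay for lipophilicity, read by LC-MS, using the shake flask method, in phosphate buffer, measured as octanol-water partition, with a stated time of 2 h, at pH 7.4; on this read-out lower numbers stand for lower lipophilicity and higher numbers for higher lipophilicity. The entry for compound 1 reads "not determined" (no result reported), so it offers no number to compare. Compound 2 gives 0.23. Compound 3 gives 0.68, the higher of the two numbers available.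

Compound 4 `OC[C@H]1O[C@H](Cn2cc(-c3cccnc3)nn2)[C@@H](O)[C@@H](O)[C@@H]1O` has not yet been measured in this assay. It carries pyridin-3-yl in place of the 3-chlorophenyl of compound 3 on an aromatic carbon: pyridin-3-yl in place of 3-chlorophenyl on an aromatic carbon.

Among the measured compounds shown here, only one measured step bears on this change, a number 0.45 log units higher from compound 2 to compound 3 (beyond the scatter), and it is modest. For the measured compounds named here, that step joins two rings of carbon only, so no measured step shows what a ring nitrogen does here. The chlorine leaves and a hydrogen-bond acceptor enters, so a larger step than that one is expected, towards a lower number. The expected change is a number 1.48 log units lower from compound 3 to compound 4 (beyond the scatter), which would lie beyond the scatter. Compound 4 is estimated at -0.8, with an expected range from -1.4 to -0.3.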

Compound 4, distribution coefficient: < -1.5
Compound 4 ended at the assay's limit; the forecaster's own chance of this, stated with the estimate: 10%; middle value at least 0.70 log units from the limit.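

The entry for compound 4 is a limit of the assay and not a number: the limit of < -1.5 in this assay, at which 1 of the 4 values shown sits.

Even so, it shows that this aromatic carbon of the five-membered ring tolerates large movement in this assay, and that the first change bringing in a ring nitrogen gives a number at least 2.18 log units lower from compound 3 to compound 4 (beyond the scatter). Set against the 4-methylphenyl group, the same ring gives a number at least 1.73 log units lower from compound 2 to compound 4 (beyond the scatter), both large next to the only step between rings of carbon only, a number 0.45 log units higher from compound 2 to compound 3 (beyond the scatter).

The compounds shown leave open how much of the change belongs to the ring nitrogen and how much to the loss of the chlorine, a question that an unsubstituted phenyl group on this carbon would address. They also leave open where an amine or a methoxy group on the pyridin-3-yl ring would fall, and how far compound 4 lies past its limit.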